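Swapping the aryl group on the core of compound 2

The source may hold more compounds than are shown below. What is called first, only, known or untested is meant among the compounds shown, and "the series" means these compounds.

Compound 1 `COc1ccc(CNC(=O)c2cc(-c3cncc(C)c3)ncc2N2CCC2)nc1OC` and compound 2 `COc1ccc(CNC(=O)c2cc(-c3cncc(C)c3)ncc2-c2ccccc2F)nc1OC` share a common core and differ only at one aromatic carbon. In an assay on CHO cells for displacement of a labelled ligand from Orexin/Hypocretin receptor type 1 variant I408V (Homo sapiens), read by scintillation counting (on this read-out lower numbers stand for stronger inhibition and higher numbers for weaker inhibition), compound 1 gives 18000 nM, while compound 2 gives 8600 nM, which is the lower of the two numbers; the step of a 2.1-fold lower number from compound 1 to compound 2 (0.32 log units; beyond the scatter) brought 2-fluorophenyl in place of azetidin-1-yl. Compound 3 `COc1ccc(CNC(=O)c2cc(-c3cncc(C)c3)ncc2-c2cnn(C)c2)nc1OC` is not yet measured and differs from compound 2 by 1-methyl-1H-pyrazol-4-yl in place of 2-fluorophenyl on an aromatic carbon. Within the data shown here, only that one measured step touches this position, and it replaced a saturated ring with an aromatic one, whereas here one aromatic ring replaces another. Compound 3 is therefore expected to land close to compound 2 in this assay, with any shift more likely a modest weakening than a gain, so the estimated step is a 1.4-fold higher number from compound 2 to compound 3 (0.14 log units; within the scatter). Compound 3 is estimated at 12000 nM, within a range of 4000 nM to 35000 nM.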

Compound 3, inhibition constant: 930 nM
For compound 3 the middle estimate is 13-fold (1.11 log units) above the measured one; measured number outside the range, below it.
By their numbers in this assay, from the lowest: compound 3; then compound 2; then compound 1.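

In this assay, 1-methyl-1H-pyrazol-4-yl in place of 2-fluorophenyl gives a 9.2-fold lower number from compound 2 to compound 3 (0.97 log units; beyond the scatter), so this position separates one aromatic ring from another, and by more than the earlier change from azetidin-1-yl to 2-fluorophenyl, a 2.1-fold lower number from compound 1 to compound 2 (0.32 log units; beyond the scatter). Measured against azetidin-1-yl, the same group gives a 19-fold lower number from compound 1 to compound 3 (1.29 log units; beyond the scatter), which leaves compound 3 with the lowest number of the three, its steps to both others lying beyond the scatter. Nothing available explains why this five-membered ring outperforms the six-membered one.

The compounds shown do not separate the contributions of ring size, the ring nitrogens and the methyl group to this shift. As far as these compounds go, it also remains open how the number would respond to an unsubstituted pyrazol-4-yl, a 1-ethyl-1H-pyrazol-4-yl or a pyridin-3-yl at this position.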